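Chalcone-triazole series: benzyl exchange on the nitro core

The source may hold more compounds than are shown below. What is called first, only, known or untested is meant among the compounds shown, and "the series" means these compounds.

Measured compounds in a functional assay on HepG2 cells (Homo sapiens) for inhibition, read by MTT assay, with a stated time of 48 h, tested at 10 uM; a lower number here means less inhibition of growth, a higher number more inhibition of growth at the concentration tested:
compound 1, `COc1ccc(C(=O)/C=C/c2ccc(OCc3cn(Cc4ccc(Br)cc4)nn3)cc2)cc1`, gives 59%;
compound 2, `COc1ccc(C(=O)/C=C/c2ccc(OCc3cn(Cc4ccccc4F)nn3)cc2)cc1`, gives 33%;
compound 3, `O=C(/C=C/c1ccc(OCc2cn(Cc3ccc(Br)cc3)nn2)cc1)c1ccc([N+](=O)[O-])cc1`, gives 21%.

Compound 4, `O=C(/C=C/c1ccc(OCc2cn(Cc3ccccc3F)nn2)cc1)c1ccc([N+](=O)[O-])cc1`, is not yet measured. Its core differs from the core of compound 1 by nitro in place of methoxy on an aromatic carbon, a change that gave a number 38 percentage points lower from compound 1 to compound 3 (beyond the scatter). Compound 2 differs from compound 1 by 2-fluorophenyl in place of 4-bromophenyl on a saturated chain carbon bound to an aromatic nitrogen, which gave a number 26 percentage points lower from compound 1 to compound 2 (beyond the scatter). Compound 4 differs from compound 3 by 2-fluorophenyl in place of 4-bromophenyl on a saturated chain carbon bound to an aromatic nitrogen; the place is the same, so this is the same change made on the core of compound 3. Because compound 3 already gives 21% and the read-out has little room to fall further, the step expected from compound 3 to compound 4 is smaller than the earlier one, estimated as a number 11 percentage points lower from compound 3 to compound 4 (beyond the scatter). Compound 4 is expected to give 10%, in a range from 0% to 25%.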

Compound 4, percent growth inhibition at one concentration: 22%
Estimate against measurement, compound 4: 12 percentage points below; low and high end bracket the measured number.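

In this assay, exchanging 4-bromobenzyl for 2-fluorobenzyl on the core of compound 3 gives a number 1 percentage points higher from compound 3 to compound 4 (within the scatter), so the step seen on the core of compound 1 does not carry over: the same change on two cores in this assay, a number 26 percentage points lower (beyond the scatter) from compound 1 to compound 2 and a number 1 percentage points higher (within the scatter) from compound 3 to compound 4, 27 percentage points apart, beyond the scatter of two such steps. The nitro for methoxy change keeps its direction on the 2-fluorobenzyl compounds, with a number 11 percentage points lower from compound 2 to compound 4 (beyond the scatter), but not its size: the same change on two cores in this assay, a number 38 percentage points lower (beyond the scatter) from compound 1 to compound 3 and a number 11 percentage points lower (beyond the scatter) from compound 2 to compound 4, 27 percentage points apart, beyond the scatter of two such steps. These four compounds show that the two changes do not simply add in this series; they do not show the reason, or how either change behaves on any other core.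

Open, going by these compounds, is how an amine or a carboxylic acid would read in place of the nitro or methoxy group. Also open, on these data alone, is how an unsubstituted benzyl or a longer chain would read on the triazole nitrogen.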